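The source may hold more compounds than are shown below. What is called first, only, known or untested is meant among the compounds shown, and "the series" means these compounds.

Compound 1 `COc1ccc(/C(C)=N/Nc2nc3ccccc3nc2Cc2ccccc2)cc1` gives 280000 nM in an assay on isolated protein for inhibition of Amine oxidase [flavin-containing] B (Homo sapiens), read by spectrophotometry (a lower number here means a stronger inhibitor, a higher number a weaker inhibitor), the lowest of the three numbers measured, though only compound 3 lies beyond the scatter of it. Compound 2 `C(=N/Nc1nc2ccccc2nc1Cc1ccccc1)\c1ccccc1` gives 320000 nM, and compound 3 `CN(C)c1ccc(/C=N/Nc2nc3ccccc3nc2Cc2ccccc2)cc1` gives 880000 nM. Within the data shown here, the single measured step, a 2.8-fold higher number from compound 2 to compound 3 (0.44 log units; beyond the scatter), is the only recorded change on that aromatic ring. Compound 4 `C/C(=N\Nc1nc2ccccc2nc1Cc1ccccc1)c1ccc(C)cc1` differs from compound 1 by methyl in place of methoxy on an aromatic carbon. Among the measured compounds shown here, no measured step exchanges methoxy for methyl, and the one measured step concerns a different group, so it offers little guidance beyond showing a modest shift. For compound 4 the expected step is a 1.1-fold higher number from compound 1 to compound 4 (0.03 log units; within the scatter), nothing beyond the scatter. The estimate for compound 4 in this assay is 300000 nM, within 130000 nM to 700000 nM.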

Compound 4, half-maximal inhibitory concentration: 740000 nM
Compound 4: middle estimate off by 2.5-fold (0.39 log units), on the low side; measured number above the stated range.
By their numbers in this assay, from the lowest: compounds 1 and 2 (each within the scatter of the next); then compounds 4 and 3 (each within the scatter of the next).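

In this assay, the change from 4-methoxyphenyl to 4-methylphenyl is not neutral: the step of a 2.6-fold higher number from compound 1 to compound 4 (0.42 log units; beyond the scatter) shows that this place, para to a large group, responds to methyl in place of methoxy. The earlier step of a 2.8-fold higher number from compound 2 to compound 3 (0.44 log units; beyond the scatter) involved dimethylamino and hydrogen, so it could not show this. Nothing available explains the step. The compounds shown leave open whether a hydroxyl or a chlorine here would sit nearer compound 1 or compound 4, and whether any group at this place would lower the number substantially.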